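Stereoinversion in a Quaternary Ammonium Oxazolidinone Pair

The compounds below may be only part of what the source reports. "The series", "measured", "known", "first", "only" and "open" are said of these compounds alone.

Measured so far:
compound 1 `CN1C[C@H](C[N+](C)(C)C)OC1=O`: 3100 nM
compound 2 `C[N+](C)(C)C[C@@H]1CNC(=O)O1`: 429 nM

In an assay on Hippocampus for displacement of a labelled ligand from Neuronal acetylcholine receptor; alpha4/beta2 (Rattus norvegicus) (on this read-out higher numbers stand for weaker inhibition and lower numbers for stronger inhibition), compound 2 gives 429 nM, the lowest of the two numbers at hand. Its nearest neighbour is compound 1, which in this assay gives 3100 nM; the gap between these two values lies beyond the usual scatter, so compound 2 is the stronger inhibitor of the pair. For the measured compounds named here, compound 1 also carries a methyl group on the ring nitrogen that compound 2 lacks, so no single-point step links them.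

The next compound, compound 3 `C[N+](C)(C)C[C@H]1CNC(=O)O1`, keeps all atoms and bonds of compound 2 and changes only one thing: the two compounds have the same atoms and bonds and differ only in configuration as drawn: 1 of 1 stereo elements differ; a stereocentre at a saturated ring carbon is drawn S in compound 2 and R in compound 3. Going by the values given here, no measured pair in this set shows what such an inversion does in this assay. A single stereocentre flip may leave the value unchanged or move it either way; the expectation is a step towards weaker inhibition, a 3.5-fold higher number from compound 2 to compound 3 (0.54 log units; beyond the scatter), with wide uncertainty. Compound 3 is thus estimated at 1500 nM, in the range 300 nM to 8000 nM.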

Compound 3, inhibition constant: 396 nM
For compound 3 the middle estimate is 3.8-fold (0.58 log units) above the measured one; measured number inside the range.
By their numbers in this assay, from the lowest: compounds 3 and 2 (each within the scatter of the next); then compound 1.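

In this assay, inverting the stereocentre at the saturated ring carbon gives a 1.1-fold lower number from compound 2 to compound 3 (0.03 log units; within the scatter) and so shows no separation between the S and R drawings in this pair. For the compounds shown here, this comparison isolates the stereocentre as the only change: the fact that compounds 2 and 3 differ only in the configuration as drawn. Hydrogen in place of methyl on the amide-type nitrogen in the ring gives a 7.8-fold lower number from compound 1 to compound 3 (0.89 log units; beyond the scatter) and provides the first single-place step in the series, so among these three compounds the number moves with the group on that nitrogen and not with the configuration.

As far as these compounds go, whether inversion has as little effect when methyl sits on the ring nitrogen remains open. Also open, from the compounds shown here alone, is what an ethyl group on that nitrogen, or a tertiary amine in place of the trimethylammonium group, would do to the number.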